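Replacing the nitro group of compound 1 with an amino group

A few compounds are considered here, and "the series" means these few. Any claim that something is new, unique, unknown or untested is made for them only; others in the source may bear on it.

Compound 1 `Cc1ccc2cccc(NS(=O)(=O)c3ccccc3[N+](=O)[O-])c2n1` gives the largest response of the three measured compounds in an assay on OCI-Ly3 cells for activation of NF-kappa-B inhibitor alpha (Homo sapiens), read by a luciferase reporter (a higher number here means a larger maximal response, a lower number a smaller maximal response), reaching 200%. Compound 2 `Cc1ccc2cccc(NS(=O)(=O)c3ccc(C(F)(F)F)cc3[N+](=O)[O-])c2n1` reaches 50%, and compound 3 `COc1cc(NS(=O)(=O)c2ccc(C)cc2[N+](=O)[O-])c2ncccc2c1` reaches 60%. Among the measured compounds shown here, the one step that changes a single place, a number 150 percentage points lower from compound 1 to compound 2 (beyond the scatter), shows that altering the ring bearing the sulfonyl group can cut the response sharply. Compound 4 `Cc1ccc2cccc(NS(=O)(=O)c3ccccc3N)c2n1` differs from compound 1 by amino in place of nitro on an aromatic carbon, placed ortho to a large group. For the measured compounds named here, no measured step covers this exact change, so the direction is uncertain; since both other variations on that ring lowered the response, a decrease is expected, with a number 100 percentage points lower from compound 1 to compound 4 (beyond the scatter). Compound 4 is therefore estimated at 100%, within the range 30% to 180%.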

Compound 4, largest response reached (reported as efficacy), in percent of the reference or control that the assay uses: 250%
Beside the measured number, compound 4's estimate is 150 percentage points below it; measured number above the stated range.
By their numbers in this assay, from the lowest: compounds 2 and 3 (each within the scatter of the next); then compound 1; then compound 4.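

At this place on an aromatic carbon, ortho to a large group, amino in place of nitro gives a number 50 percentage points higher from compound 1 to compound 4 (beyond the scatter) in this assay. The nitro group is therefore not required for a large response, and the only earlier single-place step on this ring had shown a loss. Nothing shown gives a reason for this rise. From the compounds shown here alone, whether a hydroxyl group or an acetamide at this place would give a similar response remains open, as does whether amino keeps its gain when trifluoromethyl is also on the ring.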